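Alkoxy chain variation in a benzyl-aryl imidazoline series

The source may hold more compounds than are shown below. What is called first, only, known or untested is meant among the compounds shown, and "the series" means these compounds.

Measured so far:
compound 1, `CCOc1ccc(Cc2ccc(NC3=NCCN3)cc2)cc1`, 8.2
compound 2, `CC(C)Oc1ccc(Cc2ccc(NC3=NCCN3)cc2)cc1`, 8.8
compound 3, `CC(C)COc1ccc(Cc2ccc(NC3=NCCN3)cc2)cc1`, 8.8

Among the compounds with values here, in a functional assay on SH-SY5Y cells (Homo sapiens) for antagonist activity, read by cAMP accumulation (on this read-out higher numbers stand for higher potency (the scale is a negative logarithm) and lower numbers for lower potency), compound 3 gives 8.8, level with compound 2 and together with it the highest of the three numbers; the only clear step among them is a number 0.60 log units higher from compound 1 to compound 3 (beyond the scatter), matched by a number 0.60 log units higher from compound 1 to compound 2 (beyond the scatter), while no change at the digits printed from compound 2 to compound 3 (within the scatter). Compound 4, `COCCOc1ccc(Cc2ccc(NC3=NCCN3)cc2)cc1`, differs from compound 3 in one place: methoxymethyl in place of isopropyl on a saturated chain carbon bound to an oxygen on an aromatic ring. Within the data shown here, no measured step introduces an oxygen into the chain, so the prior steps bear only loosely on it; since lengthening the chain from compound 2 gave no change at the digits printed from compound 2 to compound 3 (within the scatter), a step of modest size, most likely downward, is expected. Compound 4 is therefore estimated at 8.3, between 7.7 and 8.9, a step of a number 0.50 log units lower from compound 3 to compound 4 (beyond the scatter).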

Compound 4, negative logarithm of the antagonist equilibrium constant: 8
Estimate against measurement, compound 4: 0.30 log units above, and the stated range covers the measured number.
By their numbers in this assay, from the lowest: compounds 4 and 1 (each within the scatter of the next); then compounds 2 and 3 (each within the scatter of the next).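

In this assay, this position had shown only gains or a flat step, but methoxymethyl in place of isopropyl on the saturated chain carbon bound to an oxygen on an aromatic ring gives the first loss: a number 0.80 log units lower from compound 3 to compound 4 (beyond the scatter). Likewise, 2-methoxyethyl in place of isopropyl gives a number 0.80 log units lower from compound 2 to compound 4 (beyond the scatter). Methoxy in place of hydrogen on the saturated chain carbon, two bonds along the chain from the oxygen on the aromatic ring, gives a number 0.20 log units lower from compound 1 to compound 4 (within the scatter), so compound 4 keeps none of the gain shown by compound 2 and compound 3.

Nothing available explains this loss. From the compounds shown here alone, whether a terminal amine or a longer ether chain at this position would read the same stays open.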